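Adding Fluorine to a Pair of Non-Cytotoxic Compounds

The source may hold more compounds than are shown below. What is called first, only, known or untested is meant among the compounds shown, and "the series" means these compounds.

Compound 1, `CS(=O)(=O)c1ccc(-c2csc(N3N=C(c4ccc(Cl)s4)CC3c3ccc(F)cc3)n2)cc1`: in an ADME assay on NIH3T3 cells (Mus musculus) for cytotoxicity, read by XTT assay, with a stated time of 24 h (a lower number here means a stronger inhibitor, a higher number a weaker inhibitor), compound 1 gives > 500 ug/mL, which is a limit of the assay, not a number.
Compound 2, `Fc1ccc(C2CC(c3ccc(Cl)s3)=NN2c2nc(-c3ccccc3)cs2)cc1`: in this assay compound 2 gives > 500 ug/mL, again a limit rather than a number.

Both measured values sit at the limit of > 500 ug/mL in this assay, at which 2 of the 2 values shown sit, so the step that the two limits leave unreadable from compound 1 to compound 2 cannot be sized. Compound 2 thus stands only at a limit. Compound 3, `Fc1ccc(-c2csc(N3N=C(c4ccc(Cl)s4)CC3c3ccc(F)cc3)n2)cc1`, differs from compound 2 by fluoro in place of hydrogen on an aromatic carbon. For the measured compounds named here, the single measured step shows only that this pair stays beyond the limit, so no change beyond the scatter is expected. Compound 3 is therefore estimated at 500 ug/mL (range 250 ug/mL to 1000 ug/mL), most likely reported again as a limit, an expected step of a number no higher from compound 2 to compound 3 (the limit leaves the size open).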

Compound 3, half-maximal inhibitory concentration: > 500 ug/mL
Compound 3 was reported as a limit; the forecaster's own chance of this, stated with the estimate: 85%; the middle value lies on the limit itself.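

For the compounds shown here, no step between compound 1, compound 2 and compound 3 can be read, because each value is a limit of the assay and not a number: the limit of > 500 ug/mL in this assay, at which 3 of the 3 values shown sit. The compounds shown leave open how strongly each acts on these cells, and whether swapping these groups changes that.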